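Methyl for methoxy on a pyridine ring: half-life at low pH

The compounds below may be only part of what the source reports. "The series", "measured", "known", "first", "only" and "open" are said of these compounds alone.

Measured compounds:
compound 1, `COc1cnc(C[S+]([O-])c2nc3cc(OC(F)(F)C(F)F)ccc3[nH]2)cc1OC`, 0.317 h
compound 2, `COc1cc(C[S+]([O-])c2nc3cc(OC(F)(F)C(F)F)ccc3[nH]2)ncc1C`, 0.1 h
compound 3, `COc1ccnc(C[S+]([O-])c2nc3cc(F)c(OC(F)F)cc3[nH]2)c1OC`, 0.433 h

In an ADME assay, at pH 3 (a higher number here means that the compound lasts longer, a lower number that the compound disappears faster), compound 1 gives 0.317 h, while compound 2 gives 0.1 h. Going by the values given here, the one change between them is methyl in place of methoxy on an aromatic carbon, and it brought a 3.2-fold lower number from compound 1 to compound 2 (0.50 log units; beyond the scatter). Compound 3 gives the highest of the three numbers, 0.433 h; its gap to compound 1 lies within the scatter, its gap to compound 2 beyond it. The difference between the core of compound 3 and the core of compound 1 is not broken down here.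

Compound 4, `COc1ccnc(C[S+]([O-])c2nc3cc(F)c(OC(F)F)cc3[nH]2)c1C`, is not yet measured. It differs from compound 3 by methyl in place of methoxy on an aromatic carbon. This is the same kind of change as that from compound 1 to compound 2, but not the same: in compound 2 the new methyl is para to a large group, in compound 4 it is ortho to a large group. Resting on the single earlier step of a 3.2-fold lower number from compound 1 to compound 2 (0.50 log units; beyond the scatter), compound 4 is expected to show a step of a 2.9-fold lower number from compound 3 to compound 4 (0.46 log units; beyond the scatter). The estimate for compound 4 in this assay is 0.15 h, between 0.07 h and 0.35 h.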

Compound 4, half-life: 0.133 h
For compound 4 the middle estimate is 1.1-fold (0.05 log units) above the measured one; measured number inside the range.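

In this assay, methyl in place of methoxy on an aromatic carbon brought a 3.3-fold lower number from compound 3 to compound 4 (0.51 log units; beyond the scatter), and this step matches the earlier one on the other core: the same change on two cores in this assay, a 3.2-fold lower number (0.50 log units; beyond the scatter) from compound 1 to compound 2 and a 3.3-fold lower number (0.51 log units; beyond the scatter) from compound 3 to compound 4, 1.0-fold (0.01 log units) apart, within the scatter of two such steps. Across these two pairs, the change therefore carried from one core to the other with its size intact, even though the new methyl does not stand in the same place relative to the large group in each pair. Going by these compounds alone, with only two pairs, this does not show that the step would hold on other cores, and it does not show why the half-life falls.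

The compounds shown leave open how the half-life would respond to a different group in that place, such as an ethyl group, a chlorine atom or an amine. They also leave open whether the step would persist on a ring without the remaining methoxy group, which both pairs keep.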